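The compounds below may be only part of what the source reports. "The series", "measured", "known", "first", "only" and "open" are said of these compounds alone.

In a functional assay on the whole organism for antagonist activity, with Mus musculus as the target (on this read-out lower numbers stand for an effect already at smaller amounts and higher numbers for an effect only at larger amounts of compound), compound 1 (`Cc1nnc(CNC(=O)CN)n1-c1ccc(Cl)cc1C(=O)c1ccccc1`) gives 3.02 mg/kg and compound 2 (`Cc1nnc(CNC(=O)CN)n1-c1ccc(Cl)cc1C(=O)c1ccccc1Cl`) gives 0.58 mg/kg, the lower of the two numbers, so compound 2 acts at the smaller dose. Among the compounds with values here, the only measured step, a 5.2-fold lower number from compound 1 to compound 2 (0.72 log units; beyond the scatter), comes with chloro in place of hydrogen on an aromatic carbon. Compound 3 (`NCC(=O)NCc1nnc(C2CC2)n1-c1ccc(Cl)cc1C(=O)c1ccccc1Cl`) keeps that chloro and instead carries cyclopropyl in place of methyl on an aromatic carbon of the five-membered aromatic ring with 3 nitrogen: cyclopropyl in place of methyl on an aromatic carbon. Within the data shown here, no measured step covers a change at this place, so the chloro step offers only a rough sense of how far one small change can move this read-out. A shift beyond the usual scatter is therefore not expected, and the estimated change is small, a 1.4-fold higher number from compound 2 to compound 3 (0.14 log units; within the scatter). For compound 3 the expected value is 0.8 mg/kg, with an estimated range from 0.25 mg/kg to 2.5 mg/kg.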

Compound 3, dose for half-maximal effect: 2.34 mg/kg
The estimate for compound 3 lay 2.9-fold (0.47 log units) below the measured number; measured number inside the range.
By their numbers in this assay, from the lowest: compound 2; then compounds 3 and 1 (each within the scatter of the next).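

At this place on the five-membered aromatic ring, between two ring nitrogen atoms, the result shows that the read-out does respond to the group attached. In this assay the move from methyl to cyclopropyl gives a 4.0-fold higher number from compound 2 to compound 3 (0.61 log units; beyond the scatter) and so a larger dose is needed, the first sign that methyl is preferred over cyclopropyl here. Nothing available explains this shift.

Only methyl and cyclopropyl are shown at this place, so it remains open whether a hydrogen, an ethyl group or a longer chain ending in an amine would behave more like compound 2 or more like compound 3. Cyclopropyl also appears only together with the chloro group of compound 2, so its effect on the core of compound 1 is unknown.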